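Moving the hydroxy group around the pendant ring

The compounds below may be only part of what the source reports. "The series", "measured", "known", "first", "only" and "open" are said of these compounds alone.

Measured in a functional assay on aorta (Rattus norvegicus, strain Sprague-Dawley) for inhibition, with a stated time of 20 min; a lower number here means a smaller maximal response, a higher number a larger maximal response:
- compound 1 `C=CCc1c(O)cc(O)c2c1OC(c1cccc(Br)c1)CC2=O` gives 78.8%
- compound 2 `C=CCc1c(O)cc(O)c2c1OC(c1cccc(Cl)c1)CC2=O` gives 76.7%
- compound 3 `C=CCc1c(O)cc(O)c2c1OC(c1cccc(O)c1)CC2=O` gives 97.8%

Compound 3 stands highest of the three in this assay. Compound 1 and compound 2 differ only in the halogen on the aromatic carbon, and a number 2.1 percentage points lower from compound 1 to compound 2 (within the scatter), so these two sit together. Exchanging either halogen for a hydroxy group raises the maximal response: a number 19 percentage points higher from compound 1 to compound 3 (beyond the scatter) and a number 21.1 percentage points higher from compound 2 to compound 3 (beyond the scatter), both modest but clearly beyond the scatter.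

Compound 4 `C=CCc1c(O)cc(O)c2c1OC(c1ccc(O)cc1)CC2=O` is built from the same atoms as compound 3, joined differently: 4-hydroxyphenyl in place of 3-hydroxyphenyl on a saturated ring carbon. The hydroxy group stays, only its position on the pendant ring changes.

Within the data shown here, none of the measured steps moves a hydroxy group from one position to another; they only compare a hydroxy group with a halogen at the same position. What they do show is that a hydroxy-bearing ring, compound 3, gives the largest maximal response seen here. The hydroxy group is kept in compound 4, so no step beyond the scatter is expected, and a number 3.8 percentage points lower from compound 3 to compound 4 (within the scatter) is the estimated change. Compound 4 is therefore expected to give 94% in this assay, within a range from 80% to 105%.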

Compound 4, largest response reached (Emax), in percent of the reference or control that the assay uses: 9.86%
For compound 4 the middle estimate is 84.1 percentage points above the measured one; the whole stated range lies above it.
By their numbers in this assay, from the lowest: compound 4; then compounds 2 and 1 (each within the scatter of the next); then compound 3.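

Changing 3-hydroxyphenyl to 4-hydroxyphenyl on the saturated ring carbon next to the ring oxygen gives a number 87.9 percentage points lower from compound 3 to compound 4 (beyond the scatter) in this assay, so the place of the hydroxy group on the pendant ring matters far more here than the earlier exchange of a halogen for a hydroxy group suggested. A hydroxy group alone therefore does not bring a high maximal response: compound 3 fits that idea, but compound 4 goes against it, with a number 66.8 percentage points lower from compound 2 to compound 4 (beyond the scatter) and a number 68.9 percentage points lower from compound 1 to compound 4 (beyond the scatter) placing it well under both halogen compounds. The compounds shown offer no measured explanation for this sharp drop.

Among these compounds, whether any group at this position lowers the response, or only the hydroxy group does, remains open, since the only compound carrying a 4-substituted ring is compound 4. A 4-chlorophenyl or 4-bromophenyl ring would pair directly with compound 2 or compound 1, while a 4-methoxyphenyl or 4-aminophenyl ring would test whether an ether or an amine behaves like the hydroxy group there.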